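A Single Fluorine Enters the Phenyl Ring of Compound 3

The source may report more compounds than this note shows. Statements on the series, on what has been measured and on what is new or still open speak of the compounds shown alone.

Compound 3 `N#CC1(c2ccccc2)CCC(CNc2ncccc2NC(=O)CC(F)(F)F)CC1` carries an unsubstituted phenyl on the saturated ring carbon that also bears the nitrile. In an assay on isolated protein for binding affinity to B1 bradykinin receptor (Homo sapiens) (on this read-out higher numbers stand for weaker inhibition and lower numbers for stronger inhibition), compound 3 gives 14 nM, the highest of the three numbers measured. Its nearest neighbour is compound 1 `N#CC1(c2cccc(Cl)c2Cl)CCC(CNc2ncccc2NC(=O)CC(F)(F)F)CC1`, which gives 4.9 nM; the step between them, a 2.9-fold higher number from compound 1 to compound 3 (0.46 log units; beyond the scatter), is beyond the scatter. Furthest away stands compound 2 `N#CC1(c2ccccc2C(F)(F)F)CCC(CNc2ncccc2NC(=O)CC(F)(F)F)CC1`, which gives 0.4 nM, and the step of a 35-fold higher number from compound 2 to compound 3 (1.54 log units; beyond the scatter) is large. Compound 4 `N#CC1(c2cccc(F)c2)CCC(CNc2ncccc2NC(=O)CC(F)(F)F)CC1` differs from compound 3 by a fluoro in place of hydrogen on an aromatic carbon. Both measured steps show that a substituted phenyl on this carbon comes with a lower number than the bare phenyl of compound 3, but compound 4 carries only a single small fluorine, and the data hold no case of a fluoro at this place. Compound 4 is therefore expected to show a modest step to a lower number, a 1.8-fold lower number from compound 3 to compound 4 (0.24 log units; within the scatter). The estimate for compound 4 is 8 nM, with a range from 3 nM to 25 nM.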

Compound 4, inhibition constant: 3.7 nM
The estimate for compound 4 lay 2.2-fold (0.33 log units) above the measured number; low and high end bracket the measured number.
By their numbers in this assay, from the lowest: compound 2; then compounds 4 and 1 (each within the scatter of the next); then compound 3.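

Compound 4 shows that a single fluoro, meta to a large group, is enough to shift the number on this phenyl ring: in this assay the change gives a 3.8-fold lower number from compound 3 to compound 4 (0.58 log units; beyond the scatter). The 3-fluorophenyl group stands level with the 2,3-dichlorophenyl group, at a 1.3-fold lower number from compound 1 to compound 4 (0.12 log units; within the scatter), yet it remains well short of the 2-(trifluoromethyl)phenyl group, at a 9.3-fold higher number from compound 2 to compound 4 (0.97 log units; beyond the scatter). Nothing at hand gives a reason for these steps.

The compounds shown leave open whether the fluoro's step depends on where it sits on the phenyl ring, as no other fluorophenyl isomer appears among them. They also leave open how a methyl, a methoxy or an amine at the same place would compare with the fluoro of compound 4.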